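Methoxy in place of chloro: compound 3 to compound 4

The source may hold more compounds than are shown below. What is called first, only, known or untested is meant among the compounds shown, and "the series" means these compounds.

Among the compounds with values here, in a functional assay on SW480 cells (Homo sapiens) for antiproliferative activity, read by MTT assay, with a stated time of 48 h (a higher number here means a weaker inhibitor, a lower number a stronger inhibitor), compound 3 (`CCCCCCCC(CCO)n1cnc2c(Cl)ncnc21`) gives 3630 nM as the only number. Compound 1 (`CCCCCC(CCO)n1cnc2c(OC)ncnc21`) gives > 50000 nM as a limit and not a number. Compound 2 (`CCCCCCC(CCO)n1cnc2c(OC)ncnc21`) likewise gives > 50000 nM as a limit. Compound 4 (`CCCCCCCC(CCO)n1cnc2c(OC)ncnc21`) keeps the chain of compound 3 and takes methoxy in place of chloro on an aromatic carbon. Within the data shown here, the one measured step (a step that the two limits leave unreadable from compound 1 to compound 2) lies in the chain and gives no size. The nearest guide is the limit of > 50000 nM in this assay, at which 2 of the 3 values shown sit, and it holds compound 1 and compound 2, both methoxy, though with other chains. A weakening beyond the scatter is therefore expected in this assay and the estimate means an 11-fold higher number from compound 3 to compound 4 (1.04 log units; beyond the scatter) as an expected step. Compound 4 is estimated at 40000 nM with an expected range of 12000 nM to 80000 nM in this series.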

Compound 4, half-maximal inhibitory concentration: 23900 nM
For compound 4 the middle estimate is 1.7-fold (0.22 log units) above the measured one; the range from low to high includes it.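

Held on one chain, methoxy in place of chloro on the aromatic carbon next to the ring nitrogen gives, in this assay, a 6.6-fold higher number from compound 3 to compound 4 (0.82 log units; beyond the scatter), so this position responds to the change with a measurable size. Methoxy does not remove all readable activity, as lengthening the chain among the methoxy compounds gives an at least 2.0-fold lower number from compound 2 to compound 4 (0.32 log units; beyond the scatter) and an at least 2.0-fold lower number from compound 1 to compound 4 (0.32 log units; beyond the scatter). Both of these steps rest on limits of the assay, the only results for compound 1 and compound 2: the limit of > 50000 nM in this assay, at which 2 of the 4 values shown sit.

From the compounds shown here alone, whether an amine at this position would match compound 3 stays open. So does whether a longer chain would strengthen the methoxy or the chloro compounds further.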